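This account rests on a few compounds, and the source may have more. Where it says the series, first, only, none or still open, it means among the compounds named here.

Compound 2 `COc1cc2c(Oc3ccc(NC(=O)c4cc(-c5ccc(C(F)(F)F)cc5)ccn4)cc3F)ccnc2cc1OCCCN1CCCCC1` is compared in a functional assay on U-87MG ATCC cells (Homo sapiens) for cytotoxicity, read by MTT assay, with a stated time of 72 h (on this read-out lower numbers stand for stronger inhibition and higher numbers for weaker inhibition), with two other compounds that share its core. Going by the values given here, compound 1 `COc1cc2c(Oc3ccc(NC(=O)c4cc(-c5ccc(F)cc5)ccn4)cc3F)ccnc2cc1OCCCN1CCCCC1` gives 12500 nM in this assay, while compound 2 gives 1630 nM, the lowest of the two numbers reported; the only step in the set, a 7.7-fold lower number from compound 1 to compound 2 (0.88 log units; beyond the scatter), is a modest one that lies beyond the scatter. Compound 3 `COc1cc2c(Oc3ccc(NC(=O)c4cc(-c5ccc(C(F)(F)F)cc5)ccn4)cc3F)ccnc2cc1OCCCN1CCCC1`, which carries a smaller saturated ring on its side chain, was entered in this assay with "not determined" (no result reported), so it adds nothing to the comparison.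

Compound 4 `COc1cc2c(Oc3ccc(NC(=O)c4cc(-c5ccccc5)ccn4)cc3F)ccnc2cc1OCCCN1CCCCC1` has not yet been measured in this assay. It differs from compound 2 by hydrogen in place of trifluoromethyl on an aromatic carbon. Among the compounds with values here, no measured step covers this exact change, but the step from compound 1 to compound 2 shows that the trifluoromethyl group on this ring is tied to a lower number than fluoro. Removing the trifluoromethyl group altogether is therefore expected to move the number back up, by an amount estimated as a 5.5-fold higher number from compound 2 to compound 4 (0.74 log units; beyond the scatter) in this assay. For compound 4 the estimate in this assay is 9000 nM, with a range from 3000 nM to 30000 nM.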

Compound 4, half-maximal inhibitory concentration: 790 nM
Beside the measured number, compound 4's estimate is 11-fold (1.06 log units) above it; the whole stated range lies above it.
By their numbers in this assay, from the lowest: compound 4; then compound 2; then compound 1.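

In this assay, the step of a 2.1-fold lower number from compound 2 to compound 4 (0.31 log units; beyond the scatter) reverses the impression left by the earlier pair, and the step of a 16-fold lower number from compound 1 to compound 4 (1.20 log units; beyond the scatter) is the largest among the three compounds. Trifluoromethyl had looked favourable at this position, para to a large group, but that held only relative to fluoro: with hydrogen as the reference, both substituents go with a higher number, fluoro by far the more so. The order from the lowest number is thus hydrogen, trifluoromethyl, fluoro, and nothing available here explains why the two substituents differ so much from hydrogen or from each other.

On these data alone, whether any group at this place can bring the number below that of the unsubstituted phenyl stays open, for instance a chloro, methoxy or amine group, or whether such groups would also fall above hydrogen. As far as these compounds go, it is equally open whether the same order would hold with a side chain other than the one shared by these three compounds, such as one ending in morpholine.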